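Chloro in Place of Benzyloxy: An Expected Cytotoxicity Reading

The source may report more compounds than this note shows. Statements on the series, on what has been measured and on what is new or still open speak of the compounds shown alone.

Compound 2 `CCOC(=O)CCCCCOc1cccc(CN(C(=O)c2ccc(-c3cccc(OCc4ccccc4)c3)cc2)C(C)C)c1` was examined in an ADME assay on Raji cells (Homo sapiens) for cytotoxicity, read by CellTiter-Glo and resazurin assay, with a stated time of 72 h; on this read-out lower numbers stand for an effect already at smaller amounts and higher numbers for an effect only at larger amounts of compound. In this assay compound 2 returned only a limit, > 26000 nM, and not a number. Compound 1 `CCOC(=O)CCCCCOc1cccc(CN(C(=O)c2ccc(-c3cccc4ccccc34)cc2)C(C)C)c1`, which carries a different substituent on its outer aromatic ring, also returned only a limit in this assay, namely > 26000 nM. Within the data shown here, both readings are therefore (the limit of > 26000 nM in this assay, at which 2 of the 2 values shown sit), so compound 2 stands at the same limit as the one other compound measured, and no measured step separates the two. Compound 3 `CCOC(=O)CCCCCOc1cccc(CN(C(=O)c2ccc(-c3cccc(Cl)c3)cc2)C(C)C)c1` has not yet been measured in this assay. It differs from compound 2 in one place, (chloro in place of benzyloxy on an aromatic carbon). With both measured compounds sitting at a limit, the step that the limit leaves unreadable from compound 2 to compound 3 that the estimate implies is expected to be none beyond the scatter. For compound 3 the estimated half-maximal effective concentration in this assay is 30000 nM, expected to fall between 15000 nM and 80000 nM, most probably again reported only as a limit.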

Compound 3, half-maximal effective concentration: > 18400 nM
Compound 3: no number, only a limit (the forecaster's own chance of this, stated with the estimate: 75%); the middle value lies beyond the limit too.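

Compound 1, compound 2 and compound 3 all gave only limits in this assay, so the steps from compound 1 and from compound 2 to compound 3 cannot be read. The compounds shown leave open where any of the three reaches its half-maximal effect, and whether these substituent changes alter it at all.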